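Furan in place of dichlorophenyl on a naphthyl amide

A few compounds are considered here, and "the series" means these few. Any claim that something is new, unique, unknown or untested is made for them only; others in the source may bear on it.

Measured so far in an assay on LtK cells with ATP-sensitive inward rectifier potassium channel 11 (Homo sapiens) as the target; on this read-out lower numbers stand for an effect already at smaller amounts and higher numbers for an effect only at larger amounts of compound:
compound 1, `O=C(Nc1c(C(O)(C(F)(F)F)C(F)(F)F)ccc2ccccc12)c1cccc(Br)c1`, gives 80 nM
compound 2, `N#Cc1cccc(C(=O)Nc2c(C(O)(C(F)(F)F)C(F)(F)F)ccc3ccccc23)c1`, gives 12 nM
compound 3, `O=C(Nc1c(C(O)(C(F)(F)F)C(F)(F)F)ccc2ccccc12)c1ccc(Cl)c(Cl)c1`, gives 194 nM

Compound 3 stands at the highest number of the three in this assay; its nearest neighbour is compound 1, and the gap to compound 2 is the widest, as the step of a 16-fold higher number from compound 2 to compound 3 (1.21 log units; beyond the scatter) shows. The two measured steps that alter the ring on the carbonyl carbon both point the same way: the step of a 2.4-fold higher number from compound 1 to compound 3 (0.38 log units; beyond the scatter) is modest, the step of a 16-fold higher number from compound 2 to compound 3 (1.21 log units; beyond the scatter) is large, so among these three the 3,4-dichlorophenyl group sits at the weak end of the series and the 3-cyanophenyl group at the strong end.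

Compound 4, `O=C(Nc1c(C(O)(C(F)(F)F)C(F)(F)F)ccc2ccccc12)c1ccco1`, differs from compound 3 at that same place: furan-2-yl in place of 3,4-dichlorophenyl on a carbonyl carbon. Among the measured compounds shown here, no measured step here swaps a six-membered ring for a five-membered one, so the direction of this change rests only on the fact that every departure from the 3,4-dichlorophenyl group seen so far gave a lower number. A step downward, though a guarded one, is therefore expected: a 2.2-fold lower number from compound 3 to compound 4 (0.33 log units; beyond the scatter). Compound 4 is estimated at 90 nM in this assay, with a likely range from 25 nM to 350 nM.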

Compound 4, half-maximal effective concentration: 9 nM
For compound 4 the middle estimate is 10-fold (1.00 log units) above the measured one, outside the stated range (below it).
By their numbers in this assay, from the lowest: compounds 4 and 2 (each within the scatter of the next); then compound 1; then compound 3.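

In this assay, the ring on the carbonyl carbon proves not to need six members or any substituent to reach the low end of the series: furan-2-yl, with fewer heavy atoms than 3,4-dichlorophenyl, gives a 22-fold lower number from compound 3 to compound 4 (1.33 log units; beyond the scatter) and an 8.9-fold lower number from compound 1 to compound 4 (0.95 log units; beyond the scatter). Set against the 3-cyanophenyl group, the same ring gives a 1.3-fold lower number from compound 2 to compound 4 (0.12 log units; within the scatter), so a bare five-membered ring with one hetero atom and a six-membered carbon ring bearing a nitrile cannot be told apart at this place, and size alone does not order the four compounds. Nothing measured here says what lies behind these steps.

On these data alone, it remains open whether the ring oxygen of furan-2-yl matters, since a thiophene-2-yl, a pyrrol-2-yl or an unsubstituted phenyl ring at this place could separate the hetero atom from the ring size. As far as these compounds go, it is equally open whether a methyl group or a bromine on the furan ring would keep the number low or move it towards that of compound 3.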